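Swapping the Thiophene for a Tolyl Group

A few compounds are considered here, and "the series" means these few. Any claim that something is new, unique, unknown or untested is made for them only; others in the source may bear on it.

Going by the values given here, compound 2 `O=C(/C=C/c1cccs1)Nc1ccc2ncnc(Nc3cccc(Cl)c3)c2c1` gives 9.23 ug/mL in a functional assay on A549 cells (Homo sapiens) for antiproliferative activity, read by MTT assay, with a stated time of 48 h (a lower number here means a stronger inhibitor, a higher number a weaker inhibitor), the highest of the two numbers measured so far. Compound 1 `O=C(/C=C/c1ccccc1Br)Nc1ccc2ncnc(Nc3cccc(Cl)c3)c2c1` gives 5.63 ug/mL in the same assay. The gap between them, a 1.6-fold higher number from compound 1 to compound 2 (0.21 log units; within the scatter), is an exchange of one aryl group for another. Compound 3 `Cc1ccc(/C=C/C(=O)Nc2ccc3ncnc(Nc4cccc(Cl)c4)c3c2)cc1` differs from compound 2 by 4-methylphenyl in place of thiophen-2-yl on a double-bonded chain carbon bound to a double-bonded chain carbon. Among the compounds with values here, the only measured step that bears on such an aryl exchange is a 1.6-fold higher number from compound 1 to compound 2 (0.21 log units; within the scatter), which stayed within the scatter, so no step beyond the scatter is expected in this assay in either direction. Compound 3 is therefore estimated at 6.5 ug/mL, with a range of 3 ug/mL to 14 ug/mL, meaning a 1.4-fold lower number from compound 2 to compound 3 (0.15 log units; within the scatter).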

Compound 3, half-maximal inhibitory concentration: 6.03 ug/mL
For compound 3 the middle estimate is 1.1-fold (0.03 log units) above the measured one, and the stated range covers the measured number.
By their numbers in this assay, from the lowest: compounds 1, 3 and 2 (each within the scatter of the next).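

The change to 4-methylphenyl gives a 1.5-fold lower number from compound 2 to compound 3 (0.18 log units; within the scatter) and a 1.1-fold higher number from compound 1 to compound 3 (0.03 log units; within the scatter) in this assay and so adds a third aryl group at this place that the numbers cannot tell apart from the others. Thiophen-2-yl, a five-membered ring with sulfur, and the six-membered carbon rings 2-bromophenyl and 4-methylphenyl all stay within the scatter of one another. Nothing measured gives a reason for this result. The compounds shown leave open whether a non-aromatic group here, such as an amine or a carboxylic acid, would move the number beyond the scatter.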